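A few compounds are considered here, and "the series" means these few. Any claim that something is new, unique, unknown or untested is made for them only; others in the source may bear on it.

Within the data shown here, compound 1 `COc1ccc(C(=O)/C=C/c2ccc(N(C)C)cc2)c2c1C=CC(C)(C)O2` is the only compound of the set with a plain number in a functional assay on SW-620 cells (Homo sapiens) for antiproliferative activity, read by MTT assay, with a stated time of 24 h; on this read-out lower numbers stand for stronger inhibition and higher numbers for weaker inhibition: compound 1 gives 570 nM. Compound 2 `COc1ccc(C(=O)/C=C/c2ccc(-c3ccccc3)cc2)c2c1C=CC(C)(C)O2` reaches only the limit of this assay, > 10000 nM. Compound 3 `COc1ccc(C(=O)/C=C/c2ccc(N(c3ccccc3)c3ccccc3)cc2)c2c1C=CC(C)(C)O2` likewise reaches only the limit, > 10000 nM. Two of the three values therefore sit at that limit (the limit of > 10000 nM in this assay, at which 2 of the 3 values shown sit). Among the measured compounds shown here, the one measured step, an at least 17-fold higher number from compound 1 to compound 2 (1.24 log units; beyond the scatter), shows how far the number can rise once the dimethylamino group is gone. Compound 4 `COc1ccc(C(=O)/C=C/c2cc(Cl)ccc2O)c2c1C=CC(C)(C)O2` has not yet been measured; it differs from compound 1 by 5-chloro-2-hydroxyphenyl in place of 4-(dimethylamino)phenyl on a double-bonded chain carbon bound to a double-bonded chain carbon. For the measured compounds named here, this change again removes the dimethylamino group while bringing in a hydroxyl and a chlorine, so the step of an at least 17-fold higher number from compound 1 to compound 2 (1.24 log units; beyond the scatter) is the only guide, and it points to a large rise in the number. In this assay compound 4 is therefore expected to show a clear weakening, an 8.8-fold higher number from compound 1 to compound 4 (0.94 log units; beyond the scatter), although a number rather than a limit may still be reported. The estimate for compound 4 in this assay is 5000 nM, within the range 1500 nM to 20000 nM.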

Compound 4, half-maximal inhibitory concentration: 4230 nM
Compound 4: the middle estimate sits 1.2-fold (0.07 log units) above what was measured; low and high end bracket the measured number.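

In this assay, replacing the group on this chain carbon gives a 7.4-fold higher number from compound 1 to compound 4 (0.87 log units; beyond the scatter), so the number rises without the dimethylamino group, yet compound 4 still gives a plain number. Losing the dimethylamino group therefore does not by itself push a compound to the end of the measurable range, as the 5-chloro-2-hydroxyphenyl group shows. Compound 2 and compound 3 give limits rather than numbers: the limit of > 10000 nM in this assay, at which 2 of the 4 values shown sit.

Because compound 4 brings in a hydroxyl and a chlorine in a single change, the compounds shown cannot tell which of the two, if either, keeps its number measurable. Also open, going by these compounds, is whether a methoxy group in place of the hydroxyl, or a fluorine or bromine in place of the chlorine, would give a similar number.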